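Chain lengthening from compound 2 to compound 4

The source may hold more compounds than are shown below. What is called first, only, known or untested is meant among the compounds shown, and "the series" means these compounds.

Measured in a functional assay on HCT-116 cells (Homo sapiens) for cytotoxicity, read by MTT assay, with a stated time of 72 h; a higher number here means a weaker inhibitor, a lower number a stronger inhibitor:
compound 1 `CS(=O)(=O)NCCCN(c1nc(C(=O)NCc2ccc(F)cc2)c(O)c2ncccc12)S(C)(=O)=O` gives 7000 nM
compound 3 `CS(=O)(=O)NCCCCCCN(c1nc(C(=O)NCc2ccc(F)cc2)c(O)c2ncccc12)S(C)(=O)=O` gives 4000 nM
compound 2 `NCCNc1c(C(=O)NCc2ccc(F)cc2)nc(Br)c2cccnc12` gives only a limit of the assay, stated below

In this assay compound 2 gives > 20000 nM, which is a limit of the assay and not a number, so it stands at the limit of > 20000 nM in this assay, at which 1 of the 3 values shown sits. Compound 4 `NCCCCCCNc1c(C(=O)NCc2ccc(F)cc2)nc(Br)c2cccnc12` is not yet measured; it differs from compound 2 by 4-aminobutyl in place of amino on a saturated chain carbon, two bonds along the chain from a nitrogen on an aromatic ring. For the measured compounds named here, the only measured step of a comparable kind, lengthening a saturated chain, is a 1.8-fold lower number from compound 1 to compound 3 (0.24 log units; within the scatter), and it stays within the scatter. Going by the values given here, no measured step starts from compound 2 itself. Compound 4 is therefore expected to remain weak, at an estimated 25000 nM with a range from 10000 nM to 60000 nM, most likely again reported only as a limit. The implied step that the limit leaves unreadable from compound 2 to compound 4 is expected to lie within the scatter.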

Compound 4, half-maximal inhibitory concentration: > 10000 nM
Compound 4: only a limit was reported (the forecaster's own chance of this, stated with the estimate: 70%); the middle value lies beyond the limit too.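

For the compounds shown here, compound 2 and compound 4 are both reported only as limits in this assay, not as numbers, so no step between them can be read. The compounds shown leave open whether (6-aminohexyl)amino in place of (2-aminoethyl)amino changes the cytotoxicity at all.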